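Oxime ester aryl variation within the shared core

This account rests on a few compounds, and the source may have more. Where it says the series, first, only, none or still open, it means among the compounds named here.

Measured so far in a functional assay on microsomes from liver (Rattus norvegicus, strain Wistar) for inhibition, read by spectrophotometry, with a stated time of 60 min; on this read-out lower numbers stand for stronger inhibition and higher numbers for weaker inhibition:
compound 1 `COc1cc(C2CC(=NOC(=O)c3ccc(Br)cc3)CC(c3ccc(O)c(OC)c3)N2C)ccc1O` gives 112000 nM
compound 2 `COc1cc(C2CC(=NOC(=O)c3ccc(O)cc3)CC(c3ccc(O)c(OC)c3)N2C)ccc1O` gives 22500 nM

Among the measured compounds shown here, compound 2 stands lowest of the two numbers in this assay; the only other number is that of compound 1, and the two are separated by the step of a 5.0-fold lower number from compound 1 to compound 2 (0.70 log units; beyond the scatter), which lies beyond the scatter.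

Compound 3 `COc1ccc(C(=O)ON=C2CC(c3ccc(O)c(OC)c3)N(C)C(c3ccc(O)c(OC)c3)C2)c(OC)c1` is not yet measured. It differs from compound 2 at the oxime ester: 2,4-dimethoxyphenyl in place of 4-hydroxyphenyl on a carbonyl carbon.

For the measured compounds named here, only one measured step bears on this change. In a 5.0-fold lower number from compound 1 to compound 2 (0.70 log units; beyond the scatter) a hydroxy in place of bromo on that aromatic carbon lowered the number. Going by the values given here, in compound 3 the hydroxy leaves again, and nothing among the measured compounds shows the 2,4-dimethoxyphenyl itself. A step back toward the number of compound 1 is therefore expected, of size a 2.7-fold higher number from compound 2 to compound 3 (0.43 log units; beyond the scatter).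

Compound 3 is estimated at 60000 nM in this assay, within 20000 nM to 180000 nM.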

Compound 3, half-maximal inhibitory concentration: 52000 nM
For compound 3 the middle estimate is 1.2-fold (0.06 log units) above the measured one; the measured number falls inside the stated range.
By their numbers in this assay, from the lowest: compound 2; then compound 3; then compound 1.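

In this assay, the oxime ester aryl position tolerates loss of the hydroxy without a full return to the bromo end of the series: a 2.3-fold higher number from compound 2 to compound 3 (0.36 log units; beyond the scatter) is matched by a 2.2-fold lower number from compound 1 to compound 3 (0.33 log units; beyond the scatter), so the 2,4-dimethoxyphenyl ester sits between the other two aryl esters, with both steps beyond the scatter. The 4-hydroxyphenyl group stays lowest of the three, yet a ring with 0 hydrogen-bond donors in this group still stands below the 4-bromophenyl ester, so the hydroxy is not the only route to a lower number than that of compound 1. No measurement on hand accounts for this order.

The contributions of the two methoxy groups cannot be separated with these compounds. As far as these compounds go, how an amine or a carboxylic acid on this aryl ring would compare remains open.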